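Adding a bromine to the other ring of a weak urea

The compounds below may be only part of what the source reports. "The series", "measured", "known", "first", "only" and "open" are said of these compounds alone.

Compound 3 `CC(C)(C)c1cc(NC(=O)Nc2cc(F)cc(F)c2)n(-c2ccccc2)n1` is the weakest stabiliser of the three measured ureas: in an assay on isolated protein for inhibition of serine/threonine-protein kinase 10 (Homo sapiens), read by thermal shift assay, tested at 10 uM (on this read-out lower numbers stand for weaker stabilisation of the target and higher numbers for stronger stabilisation of the target against heat), compound 3 gives 2.5 degrees C, compound 2 `COc1cccc(NC(=O)Nc2cc(C(C)(C)C)nn2-c2ccccc2)c1` gives 3.7 degrees C, and compound 1 `Cc1ccccc1NC(=O)Nc1cc(C(C)(C)C)nn1-c1ccccc1` gives 8.6 degrees C. The shifts a number 4.9 degrees C lower from compound 1 to compound 2 (beyond the scatter), a number 6.1 degrees C lower from compound 1 to compound 3 (beyond the scatter) and a number 1.2 degrees C lower from compound 2 to compound 3 (beyond the scatter) all concern the ring on the amide-type nitrogen. For the measured compounds named here, compound 4 `CC(C)(C)c1cc(NC(=O)Nc2cc(F)cc(F)c2)n(-c2ccc(Br)cc2)n1` differs from compound 3 at a different place, (bromo in place of hydrogen on an aromatic carbon), and no measured step touches that ring, so the data give no direction for it. The expectation for compound 4 is therefore a step close to none, a number 0.50 degrees C higher from compound 3 to compound 4 (within the scatter), with wide uncertainty. Compound 4 is estimated at 3 degrees C, between 0.5 degrees C and 6 degrees C.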

Compound 4, shift of the target's melting temperature: 0.2 degrees C
Compound 4: the middle estimate sits 2.8 degrees C above what was measured; measured number outside the range, below it.
By their numbers in this assay, from the lowest: compound 4; then compound 3; then compound 2; then compound 1.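

For the compounds shown here, the ring that the earlier steps left untouched turns out to matter: in this assay, changing phenyl to 4-bromophenyl gives a number 2.3 degrees C lower from compound 3 to compound 4 (beyond the scatter). A single bromine at this place therefore lowers the stabilisation of an already weak urea, so substitution here is not neutral in this pair. Nothing available explains this drop.

On these data alone, whether an amine or a carboxylic acid at the same place would also lower the number remains open. So does whether bromo would have a similar effect on compound 1, with its 2-methylphenyl group.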